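A few compounds are considered here, and "the series" means these few. Any claim that something is new, unique, unknown or untested is made for them only; others in the source may bear on it.

Working notes on the series. Within the data shown here, in a functional assay on CHO-K1 cells with Glucose-dependent insulinotropic receptor (Homo sapiens) as the target, read by a luciferase reporter, with a stated time of 5 h (on this read-out higher numbers stand for larger maximal responses and lower numbers for smaller maximal responses), compound 3 `CC(C)OC(=O)N1CCC(Oc2ncnc3c2CCN3c2ccc(C#N)cc2F)CC1` gives 134%, the second highest of the three numbers so far; compound 2 `CC(C)OC(=O)N1CCC(Oc2ncnc3c2CCN3c2ccc(S(C)(=O)=O)cc2)CC1` gives 154% and compound 1 `CC(C)OC(=O)N1CCC(Oc2ncnc3c2CCN3c2ccc(S(C)(=O)=O)cc2F)CC1` gives 91%. The step to compound 4 `CC(C)OC(=O)N1CCC(Oc2ncnc3c2CCN3c2ccc(S(C)(=O)=O)cn2)CC1` is 5-(methylsulfonyl)pyridin-2-yl in place of 4-cyano-2-fluorophenyl on a nitrogen on an aromatic ring in a ring. Among the measured compounds shown here, two measured steps bear on it. Removing fluoro gave a number 63 percentage points higher from compound 1 to compound 2 (beyond the scatter); the same fluoro leaves here. Cyano in place of methylsulfonyl gave a number 43 percentage points higher from compound 1 to compound 3 (beyond the scatter), and compound 4 reverses that exchange, which on its own points downward. Taken together, compound 4 carries the same methylsulfonyl and lacks the fluoro, as compound 2 does, so the number is expected to move toward that of compound 2, because a number 20 percentage points lower from compound 2 to compound 3 (beyond the scatter). Nothing measured shows what the ring nitrogen does, so a wide range is kept. Compound 4 is estimated at 145%, between 105% and 185%, which is expected to mean a step of a number 11 percentage points higher from compound 3 to compound 4 (beyond the scatter), upward and modest.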

Compound 4, largest response reached (reported as percent of maximum), in percent of the reference or control that the assay uses: 111%
For compound 4 the middle estimate is 34 percentage points above the measured one; low and high end bracket the measured number.
By their numbers in this assay, from the lowest: compound 1; then compound 4; then compound 3; then compound 2.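

In this assay, swapping the carbon-only ring for 5-(methylsulfonyl)pyridin-2-yl with the methylsulfonyl kept and no fluoro gives a number 43 percentage points lower from compound 2 to compound 4 (beyond the scatter), so the maximal response at this position depends on the aromatic ring itself and not only on its substituents. The same group still gives a number 20 percentage points higher from compound 1 to compound 4 (beyond the scatter) but also a number 23 percentage points lower from compound 3 to compound 4 (beyond the scatter), which places it in the middle of the groups compared on this nitrogen. No data at hand explain these steps.

The compounds shown leave open whether the effect of the ring nitrogen holds with another substituent, as a 5-cyanopyridin-2-yl group would show. From the compounds shown here alone, how an amine or a carboxylic acid in place of methylsulfonyl on this ring would affect the maximal response also stays open.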